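Epimer of compound 1: changing one ring stereocentre

This account rests on a few compounds, and the source may have more. Where it says the series, first, only, none or still open, it means among the compounds named here.

Measured compounds:
compound 1 `O=C(N1C[C@@H](O)C=C[C@@H]1Cc1ccccc1)n1ncc(C(O)(c2ccc(F)cc2)c2ccc(F)cc2)n1` — 251 nM
compound 2 `O=C(N1CCCCC1COc1ccc(F)cc1)n1ncc(C(O)(c2ccc(F)cc2)c2ccc(F)cc2)n1` — 200 nM

In an assay on isolated protein for inhibition of Monoacylglycerol lipase ABHD6 (Homo sapiens), read by fluorescence (on this read-out lower numbers stand for stronger inhibition and higher numbers for weaker inhibition), compound 1 gives 251 nM. Among the two measured compounds it has the highest number, but compound 2 sits within the scatter of it with 200 nM, so the two cannot be told apart on these numbers. Compound 3 `O=C(N1C[C@H](O)C=C[C@@H]1Cc1ccccc1)n1ncc(C(O)(c2ccc(F)cc2)c2ccc(F)cc2)n1` has not yet been measured. Compared with compound 1 it shows the two compounds have the same atoms and bonds and differ only in configuration as drawn: 1 of 2 stereo elements differ; a stereocentre at a saturated ring carbon is drawn S in compound 1 and R in compound 3: the two compounds have the same atoms and bonds and differ only in configuration as drawn, one stereocentre at a saturated ring carbon being drawn S in compound 1 and R in compound 3. Among the compounds with values here, no measured pair in this set reports what such a change does, so the size and direction of the step of a 1.2-fold higher number from compound 1 to compound 3 (0.08 log units; within the scatter) are expected to stay within the scatter, with a wide margin of uncertainty. Compound 3 is therefore estimated at 300 nM, with a range from 80 nM to 1200 nM.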

Compound 3, half-maximal inhibitory concentration: 39.8 nM
Compound 3: the middle estimate sits 7.5-fold (0.88 log units) above what was measured, outside the stated range (below it).
By their numbers in this assay, from the lowest: compound 3; then compounds 2 and 1 (each within the scatter of the next).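

Redrawing one stereocentre at a saturated ring carbon from S to R gives a 6.3-fold lower number from compound 1 to compound 3 (0.80 log units; beyond the scatter) in this assay. Compound 1 and compound 2 differ in more than one place, so they said nothing about this carbon; the new pair shows that its configuration alone can move the number well beyond the scatter, with the R form giving the stronger inhibition. The step can be assigned to this single stereocentre because no other part of the structure changes: the fact that compounds 1 and 3 differ only in the configuration as drawn.

From the compounds shown here alone, whether an amine in place of the ring hydroxyl would show the same dependence on configuration remains open. Also open, going by these compounds, is what inverting the second stereocentre would do, since it is drawn alike in compound 1 and compound 3.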